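Replacing a Sulfonamide with a Cyclohexyl Amide

The source may report more compounds than this note shows. Statements on the series, on what has been measured and on what is new or still open speak of the compounds shown alone.

Of the compounds shown here, three share one core and have been measured in an assay on tissue (HeLa cells) for inhibition of Indoleamine 2,3-dioxygenase 1 (Homo sapiens), with stated times of 2 h and 18 h; a higher number here means a weaker inhibitor, a lower number a stronger inhibitor. Compound 1 `C[C@H](NC(=O)[C@H](C)[C@H]1CC[C@@H](c2ccnc3ccc(F)cc32)CC1)c1ccc(Cl)cc1` gives 67 nM in this assay. Compound 3 `C[C@@H](CNC(=O)c1ccc(Cl)cc1)[C@H]1CC[C@@H](c2ccnc3ccc(F)cc32)CC1` gives 261 nM in this assay. Compound 2 `C[C@@H](NS(=O)(=O)c1ccc(Cl)cc1)[C@H]1CC[C@@H](c2ccnc3ccc(F)cc32)CC1` is the outlier: in this assay compound 2 returns only a limit, > 1000 nM, so its true value is not known, only that it lies beyond what the assay could resolve. This is shown by the limit of > 1000 nM in this assay, at which 1 of the 3 values shown sits, which places compound 2 alone at that boundary while the other two compounds give numbers.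

Compound 4 `C[C@@H](NC(=O)C1CCCCC1)[C@H]1CC[C@@H](c2ccnc3ccc(F)cc32)CC1` has not yet been measured. It differs from compound 2 in a single place: cyclohexylcarbonyl in place of (4-chlorophenyl)sulfonyl on an amine nitrogen. Among the compounds with values here, because compound 2 sits at > 1000 nM and no measured pair tracks this exact change, the size of the step can only be expected, not read from data. Compounds 1 and 3 carry an amide at a comparable position and give numbers rather than limits, so the step from compound 2 to compound 4 is expected to be a large gain in potency, an at least 5.0-fold lower number from compound 2 to compound 4 (0.69 log units; beyond the scatter). Compound 4 is therefore estimated at 200 nM, with a plausible range from 50 nM to 800 nM.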

Compound 4, half-maximal inhibitory concentration: 12 nM
Compound 4: the middle estimate sits 17-fold (1.22 log units) above what was measured; the whole stated range lies above it.
By their numbers in this assay, from the lowest: compound 4; then compound 1; then compound 3. At a limit, above all of these: compound 2.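

At this amine nitrogen, putting cyclohexylcarbonyl in place of (4-chlorophenyl)sulfonyl gives an at least 83-fold lower number from compound 2 to compound 4 (1.92 log units; beyond the scatter) in this assay. The aromatic ring and the chlorine both leave in this change, so neither is needed on this nitrogen for a low number, and a non-aromatic carbon ring attached through a carbonyl serves well here. Compound 2 has only a limit rather than a number, so this step is a minimum and its true size may be larger: the limit of > 1000 nM in this assay, at which 1 of the 4 values shown sits.

The linker and the ring change together here, so the compounds shown cannot tell how much of the gain comes from the carbonyl and how much from the cyclohexyl ring. A cyclohexylsulfonyl group on the same nitrogen would separate the two, while an acetyl group would show how much of the ring is needed at all.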